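Adding one methoxy group to compound 3

The source may report more compounds than this note shows. Statements on the series, on what has been measured and on what is new or still open speak of the compounds shown alone.

Few numbers exist so far for this series in a functional assay on UACC-62 cells (Homo sapiens) for inhibition, read by sulforhodamine B assay, with a stated time of 48 h (on this read-out higher numbers stand for weaker inhibition of growth and lower numbers for stronger inhibition of growth), and all come from one shared core. Compound 1 (`CC1(/C=C/c2ccccc2C(F)(F)F)C=CC(=O)O1`) gives 17700 nM in this set. Compound 2 (`COc1ccc(/C=C/C2(C)C=CC(=O)O2)c(OC)c1`) gives 80100 nM and compound 3 (`COc1ccc(/C=C/C2(C)C=CC(=O)O2)cc1OC`) gives 84100 nM on the same read-out. Compound 3 holds the highest of the three numbers, yet it lies within the scatter of compound 2, while compound 1 has a lower number, beyond the scatter.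

Compound 4 (`COc1ccc(/C=C/C2(C)C=CC(=O)O2)c(OC)c1OC`) follows from compound 3 by a single change (methoxy in place of hydrogen on an aromatic carbon), methoxy in place of hydrogen on an aromatic carbon. Within the data shown here, no measured pair shows this change directly. Compound 2 at 80100 nM and compound 3 at 84100 nM sit within the scatter of each other with their methoxy groups placed differently, so no step beyond the scatter is expected in this assay here. The expected change is a 1.1-fold lower number from compound 3 to compound 4 (0.05 log units; within the scatter) and it would stay within the scatter. Compound 4 is estimated at 75000 nM with an expected range from 35000 nM to 130000 nM on this reading.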

Compound 4, concentration for total growth inhibition: 71500 nM
Compound 4: middle estimate off by 1.0-fold (0.02 log units), on the high side; measured number inside the range.
By their numbers in this assay, from the lowest: compound 1; then compounds 4, 2 and 3 (each within the scatter of the next).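

In this assay, among these compounds, a 1.2-fold lower number from compound 3 to compound 4 (0.07 log units; within the scatter) and a 1.1-fold lower number from compound 2 to compound 4 (0.05 log units; within the scatter) both lie within the scatter, the first direct readings of this change. A methoxy group at this position, ortho to a group of 9 heavy atoms and ortho to a methoxy group, can therefore be carried on either of the two dimethoxy compounds without a step beyond the scatter, so this assay does not separate hydrogen from methoxy at this place. No supporting evidence bears on why the change leaves the number within the scatter.

The compounds shown leave open whether an amine, a carboxylic acid or a longer alkoxy chain at this position would give a step beyond the scatter. Among the compounds shown here, they also leave open how a ring carrying only one methoxy group would read on this scale.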